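Swapping the ring on the amine side of compound 2

The source may report more compounds than this note shows. Statements on the series, on what has been measured and on what is new or still open speak of the compounds shown alone.

Measured compounds:
- compound 1 `CC(C)(C)c1ccc(CNCCNS(=O)(=O)c2cc(C(F)(F)F)cc(C(F)(F)F)c2)cc1`: 14000 nM
- compound 2 `O=S(=O)(NCCCNCC1COc2ccccc2O1)c1cc(C(F)(F)F)cc(C(F)(F)F)c1`: 1500 nM
- compound 3 `O=S(=O)(NCCNCc1cccc2ccccc12)c1cc(C(F)(F)F)cc(C(F)(F)F)c1`: 21000 nM

All three were tested in a functional assay on A2780 cells (Homo sapiens) for inhibition, read by MTT assay, with a stated time of 72 h; a higher number here means a weaker inhibitor of growth, a lower number a stronger inhibitor of growth. Compound 2 gives the lowest number of the three, with compound 1 nearest and compound 3 furthest, both gaps beyond the scatter. Compound 4 `O=S(=O)(NCCCNCc1ccc(Cl)c(Cl)c1)c1cc(C(F)(F)F)cc(C(F)(F)F)c1` has not yet been measured. It differs from compound 2 by one change: 3,4-dichlorophenyl in place of 2,3-dihydro-1,4-benzodioxin-2-yl on a saturated chain carbon bound to an amine nitrogen.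

Among the compounds with values here, only one measured step touches a related change. The step of a 1.5-fold higher number from compound 1 to compound 3 (0.18 log units; within the scatter) swaps one ring for another at the same kind of position, and it stays within the scatter. Within the data shown here, that step, however, runs between compounds that share a shorter chain than compound 2 and compound 4, so it bears on the present change only loosely; no measured pair isolates the effect of this ring swap on the chain found in compound 2. Given that, the step is expected to be modest, a 2.7-fold higher number from compound 2 to compound 4 (0.43 log units; beyond the scatter), with wide uncertainty. Compound 4 is therefore estimated at 4000 nM, with a range from 1000 nM to 20000 nM.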

Compound 4, concentration for 50% growth inhibition: 1500 nM
The estimate for compound 4 lay 2.7-fold (0.43 log units) above the measured number; the measured number falls inside the stated range.
By their numbers in this assay, from the lowest: compounds 2 and 4 (each within the scatter of the next); then compounds 1 and 3 (each within the scatter of the next).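

In this assay the change at this position gives no change at the digits printed from compound 2 to compound 4 (within the scatter) even though the groups differ markedly. The group that leaves has one six-membered non-aromatic ring, one six-membered aromatic ring and 2 hydrogen-bond acceptors, while the group that enters has a single six-membered aromatic ring, 2 chlorine atoms and 0 hydrogen-bond acceptors. Within the data shown here, on this chain, then, the non-aromatic ring and its oxygen atoms can be given up with no loss of growth inhibition, which the earlier compounds could not show.

Still open is how a carboxylic acid on the phenyl ring in place of the chlorine atoms, or a longer chain, would read in this assay, and no pair shown differs in the chain alone. No measurement at hand explains why these two different groups give matching numbers.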